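A few compounds are considered here, and "the series" means these few. Any claim that something is new, unique, unknown or untested is made for them only; others in the source may bear on it.

Measured compounds in the series:

Compound 1 `O=C(CCc1cccc(C(F)(F)F)c1)Nc1cc(Oc2ccc3nc(NC(=O)C4CC4)sc3c2)ccc1F`. In an ADME assay on HT-29 cells (Homo sapiens) for cytotoxicity, read by luminescence and CellTiter-Glo, with a stated time of 12 h (a lower number here means that less compound is tolerated, a higher number that more compound is tolerated), compound 1 gives > 50000 nM, which is a limit of the assay and not a number.
Compound 2 `Cc1cccc(NC(=O)Nc2cc(Oc3ccc4nc(NC(=O)C5CC5)sc4c3)ccc2F)c1`. In this assay compound 2 gives > 50000 nM, again a limit.
Compound 3 `O=C(Nc1cccc(Br)c1)Nc1cc(Oc2ccc3nc(NC(=O)C4CC4)sc3c2)ccc1F`. In this assay compound 3 gives > 50000 nM, also a limit.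

Compound 3 therefore stands only at a limit, and the two other values shown are limits as well, all three sitting at the limit of > 50000 nM in this assay, at which 3 of the 3 values shown sit. The steps a step that the two limits leave unreadable from compound 1 to compound 2, a step that the two limits leave unreadable from compound 1 to compound 3 and a step that the two limits leave unreadable from compound 2 to compound 3 are consequently unreadable in size and direction; none of them shows a change in this assay.

Compound 4 `COc1cccc(NC(=O)Nc2cc(Oc3ccc4nc(NC(=O)C5CC5)sc4c3)ccc2F)c1` differs from compound 3 by methoxy in place of bromo on an aromatic carbon. Among the measured compounds shown here, every measured step on this series bears on it only in the sense that no step has yet moved any compound off the limit, and none of the three steps gives a readable size. The expected step is a number no higher from compound 3 to compound 4 (the limit leaves the size open), that is, no change beyond the scatter. Compound 4 is expected to give 50000 nM in this assay, with a range from 20000 nM to 100000 nM, most probably reported again as a limit.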

Compound 4, half-maximal cytotoxic concentration: > 50000 nM
Compound 4: no number, only a limit (the forecaster's own chance of this, stated with the estimate: 85%); the middle value lies on the limit itself.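

Compound 4 is again at a limit, so its steps from compound 1, compound 2 and compound 3 cannot be read in size or direction: the limit of > 50000 nM in this assay, at which 4 of the 4 values shown sit.

The compounds shown leave open whether the methoxy, methyl, bromo or 2-(3-(trifluoromethyl)phenyl)ethyl variants differ at all in this assay.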